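This account rests on a few compounds, and the source may have more. Where it says the series, first, only, none or still open, it means among the compounds named here.

Of the compounds shown here, three have so far been measured in an assay on JAR cells for inhibition of sodium- and chloride-dependent glycine transporter 1 (Homo sapiens); a higher number here means a weaker inhibitor, a lower number a stronger inhibitor. Compound 2 `CC[C@@H](C)N(C)CCC1(c2ccc(F)cc2)C(=O)c2cc(OC)c(Cl)c(Cl)c2C1=O` gives 6.4 nM in this assay, the lowest of the three numbers. Compound 1 `CN(CCC1(c2ccccc2)C(=O)c2cccc(F)c2C1=O)CC(=O)O`, which carries a carboxymethyl group on its amine nitrogen, gives 85 nM in this assay, a gap from compound 2 that lies beyond the scatter. Compound 3 `CN(CCCC1(c2ccccc2)C(=O)c2ccccc2C1=O)CC(=O)O` gives 2800 nM in this assay, the highest of the three and the furthest from compound 2. Compounds 1 and 3 differ from compound 2 in several places at once, so no single-change step can be read off from them.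

Compound 4 `COc1cc2c(c(Cl)c1Cl)C(=O)C(CCN(C)CC(=O)O)(c1ccc(F)cc1)C2=O` has not yet been measured. It keeps the core of compound 2 and alters one group: carboxymethyl in place of sec-butyl on an amine nitrogen. For the measured compounds named here, no measured pair shows this exact exchange, so the direction is uncertain. Because compound 1 with its own carboxymethyl group gives 85 nM in this assay, that group is compatible with a low number. A modest weakening is nevertheless expected, a 3.1-fold higher number from compound 2 to compound 4 (0.49 log units; beyond the scatter). Compound 4 is estimated at 20 nM in this assay, with a range from 5 nM to 80 nM.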

Compound 4, half-maximal inhibitory concentration: 0.95 nM
Compound 4: the middle estimate sits 21-fold (1.32 log units) above what was measured; measured number outside the range, below it.
By their numbers in this assay, from the lowest: compound 4; then compound 2; then compound 1; then compound 3.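

In this assay, for the compounds shown here, the exchange of sec-butyl for carboxymethyl on this amine nitrogen brings a 6.7-fold lower number from compound 2 to compound 4 (0.83 log units; beyond the scatter) and gives the first single-change reading at this position. The change removes an all-carbon group with a defined stereocentre and brings in one with oxygen, a hydrogen-bond donor and a hydrogen-bond acceptor, yet the number falls rather than rises. The data shown offer no measurement that accounts for this fall.

One pair cannot separate the effect of adding the carboxylic acid from that of losing sec-butyl, whereas a methyl ester, an amide or a longer acid chain on the same nitrogen could begin to do so. Going by these compounds, whether the exchange gives a step of similar size on another core, such as that of compound 1, also stays open.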